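Triazole hydroxamates: changing the aryl on the core

The source may hold more compounds than are shown below. What is called first, only, known or untested is meant among the compounds shown, and "the series" means these compounds.

Measured so far:
compound 1, `COc1ccc(-c2nc(CNc3ccc(C(=O)NO)cc3)n(-c3ccccc3)n2)cc1`: > 20000 nM
compound 2, `O=C(NO)c1ccc(NCc2nc(-c3ccccc3)nn2-c2ccc(F)cc2)cc1`: 10500 nM

In a functional assay on MGC-803 cells (Homo sapiens) for antiproliferative activity, read by MTT assay, with a stated time of 72 h (on this read-out lower numbers stand for stronger inhibition and higher numbers for weaker inhibition), compound 1 gives only a limit of the assay, > 20000 nM, so its place among the numbers is open; this is the limit of > 20000 nM in this assay, at which 1 of the 2 values shown sits. Compound 2 gives 10500 nM in this assay. Compound 3, `O=C(NO)c1ccc(NCc2nc(-c3ccccc3Cl)nn2-c2ccccc2)cc1`, differs from compound 1 by 2-chlorophenyl in place of 4-methoxyphenyl on an aromatic carbon. Among the compounds with values here, no measured step covers this change, and compound 2 differs elsewhere. The expected step in this assay is an at least 1.3-fold lower number from compound 1 to compound 3 (0.12 log units; that floor lies within the scatter), within the scatter, with a limit still possible. Compound 3 is estimated at 15000 nM, between 5000 nM and 40000 nM.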

Compound 3, half-maximal inhibitory concentration: > 20000 nM
Compound 3: a limit, no number; the forecaster's own chance of this, stated with the estimate: 40%; middle value at least 1.3-fold (0.12 log units) away from the limit.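

No step can be read from compound 1 to compound 3, because each gives only a limit and no number in this assay: the limit of > 20000 nM in this assay, at which 2 of the 3 values shown sit.

Whether 2-chlorophenyl in place of 4-methoxyphenyl on an aromatic carbon changes the read-out stays open in the compounds shown.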